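The source may hold more compounds than are shown below. What is called first, only, known or untested is meant among the compounds shown, and "the series" means these compounds.

Measured compounds in an ADME assay on MCF-10A cells (Homo sapiens) for cytotoxicity, read by CCK-8 assay and cell counting, with a stated time of 72 h; on this read-out higher numbers stand for weaker inhibition and lower numbers for stronger inhibition:

Compound 1 `COc1ccc(-c2cc3ccccc3c(-c3cccc(O)c3)n2)cc1` gives 7830 nM.
Compound 2 `COc1ccc(-c2cc3ccccc3c(-c3cccc(N)c3)n2)cc1` gives 18800 nM.
Compound 3 `COc1ccc(-c2cc3cc(C)ccc3c(-c3cccc(O)c3)n2)c(C)c1` gives 5050 nM.

Compound 4 `COc1ccc(-c2cc3cc(C)ccc3c(-c3cccc(N)c3)n2)c(C)c1` remains to be measured. The difference between the core of compound 1 and the core of compound 3 is not broken down here. The change from compound 1 to compound 2 is amino in place of hydroxy on an aromatic carbon; it gave a 2.4-fold higher number from compound 1 to compound 2 (0.38 log units; beyond the scatter). The change from compound 3 to compound 4 is amino in place of hydroxy on an aromatic carbon, the same change at the same kind of place.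

The expectation for compound 4 rests on that single earlier step: the step from compound 3 to compound 4 is expected to be a 2.4-fold higher number from compound 3 to compound 4 (0.38 log units; beyond the scatter), on the strength of a 2.4-fold higher number from compound 1 to compound 2 (0.38 log units; beyond the scatter). Compound 4 is therefore estimated at 12000 nM in this assay, between 6000 nM and 25000 nM.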

Compound 4, half-maximal inhibitory concentration: 5740 nM
The estimate for compound 4 lay 2.1-fold (0.32 log units) above the measured number, outside the stated range (below it).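

In this assay amino in place of hydroxy on the second core gives a 1.1-fold higher number from compound 3 to compound 4 (0.06 log units; within the scatter). Set beside the step on the first core, the two steps do not separate: the same change on two cores in this assay, a 2.4-fold higher number (0.38 log units; beyond the scatter) from compound 1 to compound 2 and a 1.1-fold higher number (0.06 log units; within the scatter) from compound 3 to compound 4, 2.1-fold (0.32 log units) apart, within the scatter of two such steps. Within the data shown here, the change therefore carries between these two cores with no difference between the steps that stands above the scatter, but one pair per core does not show that the step has a fixed size, nor that it would hold on any other core.

Still open, going by these compounds, is how a carboxylic acid or an acetamide would compare with hydroxy and amino at this place. Also open, on these data alone, is which part of the difference between the two cores matters for this step, if any.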